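The source may hold more compounds than are shown below. What is called first, only, known or untested is meant among the compounds shown, and "the series" means these compounds.

Measured in a functional assay on HCT-15 cells (Homo sapiens) for antiproliferative activity, read by MTT assay, with a stated time of 72 h; a higher number here means a weaker inhibitor, a lower number a stronger inhibitor:
Compound 1 `COc1cc(-c2nccn2C(C)C)cc(OC)c1OC`: > 100000 nM, a limit
Compound 2 `CCCCn1ccnc1-c1cc(OC)c(OC)c(OC)c1`: > 100000 nM, a limit
Compound 3 `COc1cc(-c2nccn2S(=O)(=O)c2ccccc2)cc(OC)c1OC`: > 100000 nM, a limit

Compound 3 stands at > 100000 nM, which is a limit and not a number. Among the measured compounds shown here, it has no measured neighbour to rank against, since the series so far shows only (the limit of > 100000 nM in this assay, at which 3 of the 3 values shown sit). The next compound, compound 4 `COc1cc(-c2nccn2S(=O)(=O)c2ccc(C)cc2)cc(OC)c1OC`, changes compound 3 at a single place: methyl in place of hydrogen on an aromatic carbon. In words, a methyl takes the place of hydrogen on an aromatic carbon, turning phenyl into 4-methylphenyl.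

For the measured compounds named here, the only measured step is a step that the two limits leave unreadable from compound 1 to compound 2. It concerns a butyl in place of an isopropyl on an aromatic nitrogen, a different change at a different place, and it has no readable size to carry over. Going by the values given here, no measured step therefore bears directly on the methyl, and no step beyond the scatter is expected in this assay, in either direction. The expected step is a number no higher from compound 3 to compound 4 (the limit leaves the size open). Compound 4 is most likely to be reported as a limit again. If a number appears, compound 4 is estimated at 100000 nM, with an expected range of 40000 nM to 200000 nM.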

Compound 4, half-maximal inhibitory concentration: > 100000 nM
Compound 4: no number, only a limit; the forecaster's own chance of this, stated with the estimate: 85%; the middle value lies on the limit itself.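

No step can be read from compound 3 to compound 4, since each is reported only as a limit in this assay: the limit of > 100000 nM in this assay, at which 4 of the 4 values shown sit.

Compounds 1 to 4 therefore leave open whether the methyl, or any other group shown on the shared core, changes activity in this assay.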